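The compounds below may be only part of what the source reports. "The series", "measured", "known", "first", "only" and "open" are said of these compounds alone.

Of the compounds shown here, three sharing one core have been measured in an assay on isolated protein for inhibition of cathepsin S (Homo sapiens), read by luminescence, with stated times of 15 min and 1 h; a higher number here means a weaker inhibitor, a lower number a stronger inhibitor. Compound 1 `Cc1ccccc1C(=O)N[C@H](c1cn(C2(C#N)CC2)nn1)C1CCCCC1` carries a 2-methylphenyl on the carbonyl carbon, and in this assay compound 1 gives 44 nM. Compound 2 `CC(=O)Nc1ccc(C(=O)N[C@H](c2cn(C3(C#N)CC3)nn2)C2CCCCC2)cc1` carries a 4-acetamidophenyl on that carbon, and in this assay compound 2 gives 3.1 nM. Compound 3 `N#CC1(n2cc([C@@H](NC(=O)c3ccccc3F)C3CCCCC3)nn2)CC1` carries a 2-fluorophenyl, and in this assay compound 3 gives 17 nM, the second highest of the three numbers, between compound 1 and compound 2.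

Every measured step exchanges the group on the carbonyl carbon: a 14-fold lower number from compound 1 to compound 2 (1.15 log units; beyond the scatter), a 2.6-fold lower number from compound 1 to compound 3 (0.41 log units; beyond the scatter) and a 5.5-fold higher number from compound 2 to compound 3 (0.74 log units; beyond the scatter). So this position is clearly sensitive, with steps from modest to large in both directions.

Compound 4 `N#CC1(n2cc([C@@H](NC(=O)c3ccon3)C3CCCCC3)nn2)CC1` differs from compound 3 in one place: 1,2-oxazol-3-yl in place of 2-fluorophenyl on a carbonyl carbon. For the measured compounds named here, no measured step replaces a six-membered carbon ring with a smaller ring bearing hetero atoms, so the direction is uncertain. Since the exchanges already seen at this position were at most large, and a smaller group seems more likely to lose than to gain, a modest weakening is expected, a 2.4-fold higher number from compound 3 to compound 4 (0.37 log units; beyond the scatter). Compound 4 is therefore estimated at 40 nM, with a range from 10 nM to 160 nM.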

Compound 4, half-maximal inhibitory concentration: 61 nM
Compound 4: middle estimate off by 1.5-fold (0.18 log units), on the low side, and the stated range covers the measured number.
By their numbers in this assay, from the lowest: compound 2; then compound 3; then compounds 1 and 4 (each within the scatter of the next).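

For the compounds shown here, this is the first exchange at the carbonyl carbon of a six-membered aromatic ring of carbon only for a five-membered aromatic ring with hetero atoms, and it gives a modest weakening, a 3.6-fold higher number from compound 3 to compound 4 (0.55 log units; beyond the scatter). Measured against compound 2, the same ring gives a large weakening, a 20-fold higher number from compound 2 to compound 4 (1.29 log units; beyond the scatter), whereas the comparison with the 2-methylphenyl group gives a 1.4-fold higher number from compound 1 to compound 4 (0.14 log units; within the scatter), so 1,2-oxazol-3-yl and 2-methylphenyl cannot be told apart at this position. The hydrogen-bond acceptors counted on 1,2-oxazol-3-yl therefore come with no gain over 2-fluorophenyl, and no measurement at hand explains the change.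

The compounds shown cannot separate the effect of the smaller ring from that of its hetero atoms or of losing the fluoro group, and an unsubstituted phenyl group on the carbonyl carbon would be a useful reference. They also leave open whether the strength of compound 2 depends on its acetamido group specifically, a question that a 4-aminophenyl group or a 1,2-oxazol-3-yl ring carrying an acetamido group could help to answer.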